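From methyl to phenyl on a shared core

The compounds below may be only part of what the source reports. "The series", "measured", "known", "first", "only" and "open" are said of these compounds alone.

Compound 1 `Cc1cc2[nH]nc(N)c2c(=O)[nH]1`: 1640 ug/mL
Compound 2 `Nc1n[nH]c2cc(-c3ccccc3)[nH]c(=O)c12`: 24 ug/mL
Compound 3 `Cc1cc2c(c(N)nn2C)c(=O)[nH]1`: 1220 ug/mL

In a physicochemical assay for solubility, read by HPLC (on this read-out lower numbers stand for lower solubility and higher numbers for higher solubility), compound 3 sits within the scatter of compound 1, and both lie well above compound 2. Compound 4 `Cn1nc(N)c2c(=O)[nH]c(-c3ccccc3)cc21` departs from compound 3 by one change: phenyl in place of methyl on an aromatic carbon. For the measured compounds named here, the only measured step, a 1.3-fold lower number from compound 1 to compound 3 (0.13 log units; within the scatter), concerns a methyl on an aromatic nitrogen, and no measured step covers this change directly. The nearest guide is the gap between compound 1 at 1640 ug/mL and compound 2, which carries a phenyl, at 24 ug/mL. A drop of similar size, well beyond the scatter, is therefore expected. The expected step is a 68-fold lower number from compound 3 to compound 4 (1.83 log units; beyond the scatter). Compound 4 is estimated at 18 ug/mL, within an expected range of 6 ug/mL to 60 ug/mL.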

Compound 4, solubility: 76 ug/mL
Compound 4: middle estimate off by 4.2-fold (0.63 log units), on the low side; measured number above the stated range.
By their numbers in this assay, from the lowest: compound 2; then compound 4; then compounds 3 and 1 (each within the scatter of the next).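

In this assay, phenyl in place of methyl on an aromatic carbon now has a measured step of its own, a 16-fold lower number from compound 3 to compound 4 (1.21 log units; beyond the scatter). Methyl in place of hydrogen on an aromatic nitrogen stayed within the scatter as a 1.3-fold lower number from compound 1 to compound 3 (0.13 log units; within the scatter), yet with phenyl present it gives a 3.2-fold higher number from compound 2 to compound 4 (0.50 log units; beyond the scatter), so that change does not read the same in both pairs. Nothing at hand explains this difference.

The compounds shown leave open where an amine or a carboxylic acid on that aromatic carbon would fall, and whether a longer chain on the aromatic nitrogen would follow the methyl.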